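Swapping phenylsulfonyl for (2-chlorophenyl)carbamoyl on the shared core

A few compounds are considered here, and "the series" means these few. Any claim that something is new, unique, unknown or untested is made for them only; others in the source may bear on it.

Measured so far in a functional assay on MDA-MB-231 cells (Homo sapiens) for antiproliferative activity, read by MTT assay, with a stated time of 24 h (on this read-out higher numbers stand for weaker inhibition and lower numbers for stronger inhibition), for three compounds
- Compound 1 `O=C1CC[C@@H](C(=O)N2CCN(c3nccc(Oc4cc(Cl)cc(Cl)c4)n3)CC2)N1` gives > 50000 nM as a limit
- Compound 2 `O=S(=O)(c1ccccc1)N1CCN(c2nccc(Oc3cc(Cl)cc(Cl)c3)n2)CC1` gives > 50000 nM as a limit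
- Compound 3 `COc1ccccc1S(=O)(=O)N1CCN(c2nccc(Oc3cc(Cl)cc(Cl)c3)n2)CC1` gives 16800 nM as a number

Compound 2 sits at the limit of > 50000 nM in this assay, at which 2 of the 3 values shown sit, and so has no number of its own. Compound 4 `O=C(Nc1ccccc1Cl)N1CCN(c2nccc(Oc3cc(Cl)cc(Cl)c3)n2)CC1` has not been measured yet. It carries (2-chlorophenyl)carbamoyl in place of phenylsulfonyl on an amine nitrogen in a ring, a change counted as (2-chlorophenyl)carbamoyl in place of phenylsulfonyl on an amine nitrogen in a ring in this one place. Among the compounds with values here, two measured steps bear on it. On that nitrogen, a step that the two limits leave unreadable from compound 1 to compound 2 gives no size. Methoxy in place of hydrogen on an aromatic carbon gave an at least 2.9-fold lower number from compound 2 to compound 3 (0.47 log units; beyond the scatter) and is the only readable step. A modest fall in this assay is therefore expected, although compound 4 may well stay at the limit. The estimate means an at least 2.0-fold lower number from compound 2 to compound 4 (0.30 log units; that floor lies within the scatter) as the expected step. For compound 4 the estimated value is 25000 nM within a range of 10000 nM to 50000 nM on this reasoning.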

Compound 4, half-maximal inhibitory concentration: 11000 nM
Compound 4: the middle estimate sits 2.3-fold (0.36 log units) above what was measured, within the range that was stated.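

Putting (2-chlorophenyl)carbamoyl in place of phenylsulfonyl on the amine nitrogen in a ring gives an at least 4.5-fold lower number from compound 2 to compound 4 (0.65 log units; beyond the scatter), so this nitrogen tolerates a change that brings a measurable value without any substituent added to phenylsulfonyl. Keeping the carbonyl and putting (2-chlorophenyl)amino in place of 5-oxopyrrolidin-2-yl gives an at least 4.5-fold lower number from compound 1 to compound 4 (0.65 log units; beyond the scatter). Both sizes are only floors, because compound 1 and compound 2 have no numbers of their own: the limit of > 50000 nM in this assay, at which 2 of the 4 values shown sit.

The compounds shown do not separate the contribution of the carbamoyl link from that of the chlorine. From the compounds shown here alone, what an amine or a carboxylic acid in place of that chlorine would do remains open.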